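Fluoro on the fused ring in a pyrazinedione series

A few compounds are considered here, and "the series" means these few. Any claim that something is new, unique, unknown or untested is made for them only; others in the source may bear on it.

Measured compounds:
compound 1, `CC(C)N(C(=O)CN1C=CN(c2ccccc2)C(=O)[C@H](Cc2n[nH]c3ccccc23)C1=O)c1ccccc1`, 295 nM
compound 2, `COc1ccc(N(C(=O)CN2C=CN(c3cccnc3)C(=O)C(Cc3n[nH]c4cc(F)ccc34)C2=O)C(C)C)cc1`, 12.6 nM
compound 3, `COc1ccc(N(C(=O)CN2C=CN(c3cccnc3)C(=O)C(Cc3n[nH]c4ccccc34)C2=O)C(C)C)cc1`, 178 nM

All three were run in a functional assay on CHO cells for agonist activity at Melanocyte-stimulating hormone receptor (Homo sapiens), read by a luciferase reporter, with a stated time of 4 h; a lower number here means that less compound is needed, a higher number that more compound is needed for the effect. Compound 1 and compound 3 have different cores; the difference between the two cores is not broken down here, and their values in this assay lie within the scatter of each other. The change from compound 3 to compound 2 is fluoro in place of hydrogen on an aromatic carbon, and it gave a 14-fold lower number from compound 3 to compound 2 (1.15 log units; beyond the scatter).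

Compound 4, `CC(C)N(C(=O)CN1C=CN(c2ccccc2)C(=O)[C@H](Cc2n[nH]c3cc(F)ccc23)C1=O)c1ccccc1`, is not yet measured. It differs from compound 1 by fluoro in place of hydrogen on an aromatic carbon, the same change, at the same place, as from compound 3 to compound 2. Resting on that single precedent, compound 4 is expected to give an 11-fold lower number from compound 1 to compound 4 (1.02 log units; beyond the scatter), a step of about the size seen from compound 3 to compound 2. The estimate for compound 4 in this assay is 28 nM, with a range from 8 nM to 120 nM.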

Compound 4, half-maximal effective concentration: 35.5 nM
Compound 4: middle estimate off by 1.3-fold (0.10 log units), on the low side; the range from low to high includes it.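

In this assay fluoro in place of hydrogen on an aromatic carbon gives an 8.3-fold lower number from compound 1 to compound 4 (0.92 log units; beyond the scatter) on the core of compound 1, so the change also lowers the number on this second core. The size of the step carries from one core to the other, with no difference between the two steps beyond the scatter: the same change on two cores in this assay, a 14-fold lower number (1.15 log units; beyond the scatter) from compound 3 to compound 2 and an 8.3-fold lower number (0.92 log units; beyond the scatter) from compound 1 to compound 4, 1.7-fold (0.23 log units) apart, within the scatter of two such steps. This rests on two pairs, both with fluoro at the same place, and shows neither why the step arises nor whether it would hold on any further core.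

On these data alone, whether chloro or a nitrile in place of that hydrogen would give a step of similar size remains open. Also open, as far as these compounds go, is how fluoro would act on the other aromatic carbons of the fused system.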